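Swapping a para substituent on the benzyl group of a CCR8 antagonist

The compounds below may be only part of what the source reports. "The series", "measured", "known", "first", "only" and "open" are said of these compounds alone.

Measured compounds:
compound 1, `COc1ccc2nccc(C3CN(C4CCN(Cc5ccccc5Cl)CC4)C(=O)O3)c2c1`, < 50200 nM
compound 2, `COc1ccc(CN2CCC(N3CC(c4ccnc5ccc(OC)cc45)OC3=O)CC2)cc1`, 1260 nM

The series shares a core carrying a benzyl group on a piperidine nitrogen. In an in vitro functional assay on RBL cells for antagonist activity at C-C chemokine receptor type 8 (Homo sapiens), read by FLIPR and calcium flux (a higher number here means a weaker inhibitor, a lower number a stronger inhibitor), compound 1 gives only a limit, < 50200 nM, so no number is known for it. For the measured compounds named here, compound 2 gives 1260 nM in this assay; this is the only actual number in the set. The step that the limit leaves unreadable from compound 1 to compound 2 cannot be sized, because the limit of < 50200 nM in this assay, at which 1 of the 2 values shown sits, hides the starting point.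

Compound 3, `COc1ccc2nccc(C3CN(C4CCN(Cc5ccc(C#N)cc5)CC4)C(=O)O3)c2c1`, differs from compound 2 by cyano in place of methoxy on an aromatic carbon. Going by the values given here, no measured step touches this change: the only measured step exchanges the benzyl substituent at a different place on the ring and its size is unreadable. With nothing to guide direction or size, the step from compound 2 to compound 3 in this assay is expected to stay within the usual scatter, a 1.3-fold higher number from compound 2 to compound 3 (0.10 log units; within the scatter). Compound 3 is therefore estimated at 1600 nM, with a range from 500 nM to 5000 nM.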

Compound 3, half-maximal inhibitory concentration: 12600 nM
Compound 3: the middle estimate sits 7.9-fold (0.90 log units) below what was measured; the measured number lies above the stated range.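

In this assay, for the compounds shown here, cyano in place of methoxy on an aromatic carbon gives a 10-fold higher number from compound 2 to compound 3 (1.00 log units; beyond the scatter), the first step in the set whose size can be read. The change therefore shows that this place, para to a large group, is not indifferent to what it carries, and that of this pair the 4-methoxybenzyl group of compound 2 gives the stronger inhibitor. The size of the step also stands against the counts for the two groups, which match in heavy atoms, hydrogen-bond donors, hydrogen-bond acceptors and net charge, so those counts alone do not predict the outcome here.

As far as these compounds go, with a single pair, it stays open whether methoxy is the favourable group or cyano the unfavourable one, and whether a hydroxyl group, an ethoxy group, an amine or a carboxylic acid at the same place would read closer to compound 2 or to compound 3. Compound 1 gives only a limit and not a number, so neither step that starts from it can be read, and the comparison of its 2-chlorophenyl group with the other two remains unsized: the limit of < 50200 nM in this assay, at which 1 of the 3 values shown sits.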